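A few compounds are considered here, and "the series" means these few. Any claim that something is new, unique, unknown or untested is made for them only; others in the source may bear on it.

Working notes on the series. Compound 1 `ClCc1ccc(Cn2cnc3c(Cl)ncnc32)cc1` has in a functional assay on SNB-75 cells (Homo sapiens) for cytotoxicity, read by sulforhodamine B assay, with a stated time of 48 h (a higher number here means that more compound is tolerated, a lower number that less compound is tolerated), only the entry "not determined" (no result reported), no number. Within the data shown here, compound 2 `Nc1nc(Cl)c2ncn(Cc3ccccc3CCl)c2n1` is the only compound with a number: in this assay compound 2 gives 64600 nM, so it stands alone as the sole reference point. Compound 3 `ClCc1ccccc1Cn1cnc2c(Cl)ncnc21` differs from compound 2 by hydrogen in place of amino on an aromatic carbon, the change sitting on an aromatic carbon of a six-membered aromatic ring with 2 nitrogen. Among the measured compounds shown here, no measured pair covers this change, so no direction is given; in this assay the step from compound 2 to compound 3 is expected to stay within the scatter, a 1.1-fold lower number from compound 2 to compound 3 (0.03 log units; within the scatter). For compound 3 the expected value is 60000 nM, ranging from 20000 nM to 180000 nM.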

Compound 3, concentration lethal to 50% of the cells: 39800 nM
Compound 3: middle estimate off by 1.5-fold (0.18 log units), on the high side, within the range that was stated.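

In this assay, among these compounds, the first measured pair for this change gives a 1.6-fold lower number from compound 2 to compound 3 (0.21 log units; within the scatter) so on this aromatic carbon between two ring nitrogen atoms, hydrogen in place of amino leaves the number within the scatter. This reading rests on a single pair, with the rest of the two structures held the same. Nothing on hand explains the result. On these data alone, whether a methylamino group or a methoxy group on this carbon would give a step beyond the scatter stays open. So does whether the same change would read alike with another group in place of the chloro group.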